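The source may hold more compounds than are shown below. What is called first, only, known or untested is meant among the compounds shown, and "the series" means these compounds.

Working notes on the series. Among the compounds with values here, compound 3 `CNc1cc(C)c(C(N)=O)cn1` is the one member with a number in an assay on isolated protein for inhibition of Nicotinamide N-methyltransferase (Homo sapiens), read by luminescence, with a stated time of 20 min (a lower number here means a stronger inhibitor, a higher number a weaker inhibitor), where compound 3 gives 282 nM. Compound 1 `CNc1ncc(C(N)=O)c(C)n1` reaches only a limit in this assay, > 10000 nM. Compound 2 `CCOc1cc(C)c(C(N)=O)cn1` likewise sits at a limit in this assay, > 10000 nM. Within the data shown here, the single measured step is an at least 35-fold lower number from compound 2 to compound 3 (1.54 log units; beyond the scatter), and the limit of > 10000 nM in this assay, at which 2 of the 3 values shown sit, marks where both other values rest. Compound 4 `CNc1cc(C(F)(F)F)c(C(N)=O)cn1` is next, and the change is trifluoromethyl in place of methyl on an aromatic carbon. Among the measured compounds shown here, no measured step touches the methyl position, so the change from compound 3 to compound 4 stands without precedent here. Compound 4 is expected to give 500 nM in this assay, within 120 nM to 2500 nM, a step of a 1.8-fold higher number from compound 3 to compound 4 (0.25 log units; within the scatter), likely within or near the scatter.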

Compound 4, half-maximal inhibitory concentration: > 10000 nM
Compound 4: a limit, no number; the forecaster's own chance of this, stated with the estimate: 10%; middle value at least 20-fold (1.30 log units) away from the limit.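

In this assay, within the data shown here, the first measured change at the methyl position gives an at least 35-fold higher number from compound 3 to compound 4 (1.54 log units; beyond the scatter), so this carbon, ortho to a carbamoyl group, is not indifferent to its substituent. Both single changes shown from compound 3, at the methylamino group and at the methyl, now end at a limit and not a number. Compound 4 reaches a limit, the reading shared across the series: the limit of > 10000 nM in this assay, at which 3 of the 4 values shown sit. Going by these compounds, how a hydrogen, a chlorine atom or an ethyl group would read at this carbon stays open. On these data alone, the full size of the loss also stays open, since a limit gives no number.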